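Swapping the side chain of compound 1 for a methoxy group

The compounds below may be only part of what the source reports. "The series", "measured", "known", "first", "only" and "open" are said of these compounds alone.

Measured compounds in an ADME assay on liver for metabolic stability, with Liver microsome (Homo sapiens) as the target, read by LC-MS, using microsomes; on this read-out higher numbers stand for fast clearance and lower numbers for slow clearance:
- compound 1, `CC1(C[C@@H](O)C(=O)N2C[C@H]3C[C@H]3[C@H]2C(=O)NCc2cc(Cl)ccc2-n2cnnn2)CC1`, 12 mL.min-1.g-1
- compound 2, `O=C(NCc1cc(Cl)ccc1-n1cnnn1)[C@@H]1CCNN1C(=O)[C@H](O)c1ccccc1`, a limit of < 16 mL.min-1.g-1
- compound 3, `O=C(NCc1cc(Cl)ccc1-n1cnnn1)[C@@H]1C[C@H]2C[C@H]2N1C(=O)[C@H](O)CC1CC1`, 25 mL.min-1.g-1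

Compound 1 holds the lowest of the two plain numbers in this assay, with compound 3 the nearest to it; the gap between compound 1 and compound 3 is beyond the usual scatter of this read-out. Among the compounds with values here, for compound 2 only a limit of the assay is reported in this assay, not a number, and that is all that can be said of it here; it also differs from compound 1 in more than one place, so no single step links them.

Compound 4, `COC(C)(C)[C@@H](O)C(=O)N1C[C@H]2C[C@H]2[C@H]1C(=O)NCc1cc(Cl)ccc1-n1cnnn1`, has not yet been measured. It differs from compound 1 in one place: 1-methoxy-1-methylethyl in place of (1-methylcyclopropyl)methyl on a saturated chain carbon bound to a carbonyl carbon and an oxygen on a saturated carbon. Within the data shown here, no measured pair in this set shows the effect of such a swap, so there is no measured step to lean on. With compound 1 already at the low end of the numbers shown, the step from compound 1 to compound 4 in this assay is expected to be small, no larger than the scatter, as a 1.1-fold lower number from compound 1 to compound 4 (0.04 log units; within the scatter). Compound 4 is therefore estimated to give 11 mL.min-1.g-1 in this assay, with a range from 5 mL.min-1.g-1 to 22 mL.min-1.g-1.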

Compound 4, intrinsic clearance in microsomes: 23 mL.min-1.g-1
Compound 4: the middle estimate sits 2.1-fold (0.32 log units) below what was measured; measured number outside the range, above it.
By their numbers in this assay, from the lowest: compounds 1, 4 and 3 (each within the scatter of the next, the first and the last beyond it).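

In this assay the place on a saturated chain carbon bound to a carbonyl carbon and an oxygen on a saturated carbon now has its first measured step, a 1.9-fold higher number from compound 1 to compound 4 (0.28 log units; within the scatter), so on the shared core this swap does not take the read-out beyond the usual scatter. The swap changes two things at once: (1-methylcyclopropyl)methyl brings a three-membered ring of carbon only and no hydrogen-bond acceptor, whereas 1-methoxy-1-methylethyl brings no ring and one hydrogen-bond acceptor, and this single step cannot separate the loss of the ring from the gain of the oxygen. Within the data shown here, the one piece of supporting information available concerns another compound and offers no explanation for this step.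

The compounds shown leave open whether an open chain of carbon only, such as tert-butyl, or a ring carrying the oxygen, such as tetrahydropyran-4-yl, would give a number like that of compound 1 or compound 4 at this place. They also leave open whether an amine, a carboxylic acid or a longer chain at this place would produce a step beyond the scatter.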